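Fixing one stereocentre of compound 2

The source may hold more compounds than are shown below. What is called first, only, known or untested is meant among the compounds shown, and "the series" means these compounds.

Among the measured compounds shown here, in a functional assay on P388 cells (Mus musculus) for inhibition (a higher number here means a weaker inhibitor, a lower number a stronger inhibitor), compound 2 `CC1(CO)OCC(n2ccc(N)nc2=O)O1` gives 10000 nM, one of only two numbers in hand; the other belongs to compound 1 `C[C@]1(CO)OC[C@@H](n2ccc(N)nc2=O)O1` at 5000 nM, with the step of a 2.0-fold higher number from compound 1 to compound 2 (0.30 log units; within the scatter) between them. Compound 3 `CC1(CO)OCC(n2cc(F)c(N)nc2=O)O1` reaches only the limit > 100000 nM in this assay. The step of an at least 10-fold higher number from compound 2 to compound 3 (1.00 log units; beyond the scatter) concerns a fluoro and does not bear on the present change. Compound 4 `C[C@]1(CO)OCC(n2ccc(N)nc2=O)O1` differs from compound 2 in that (the two compounds have the same atoms and bonds; at least one stereo element is drawn with a configuration in one of them and without one in the other: 1 of 2 stereo elements differ; a stereocentre at a saturated ring carbon is drawn without a configuration in compound 2 and S in compound 4). For the measured compounds named here, only the step from compound 1 to compound 2 bears on this, and it rests on (the fact that one of compounds 1 and 2 is drawn with a defined configuration and the other without, at the place where they differ); as it lies within the scatter, no step beyond the scatter is expected for compound 4. Compound 4 is accordingly estimated at 7000 nM, between 3000 nM and 20000 nM, a step of a 1.4-fold lower number from compound 2 to compound 4 (0.15 log units; within the scatter).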

Compound 4, half-maximal inhibitory concentration: > 100000 nM
Compound 4 was reported as a limit; the forecaster's own chance of this, stated with the estimate: 5%; middle value at least 14-fold (1.15 log units) away from the limit.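

In this assay compound 4 sits at a limit, > 100000 nM. The series now holds steps beyond the scatter with no change of atoms or bonds: an at least 10-fold higher number from compound 2 to compound 4 (1.00 log units; beyond the scatter) and an at least 20-fold higher number from compound 1 to compound 4 (1.30 log units; beyond the scatter). So the configuration drawn at a saturated ring carbon can matter in this assay as much as the fluoro step did, and this rests on drawing alone: the fact that one of compounds 2 and 4 is drawn with a defined configuration and the other without, at the place where they differ

Still open, going by these compounds, are the opposite configuration at this stereocentre and the configuration at the second stereocentre of compound 4. Also open, on these data alone, is whether an ethyl group in place of the methyl keeps the inhibition of compound 1.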